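This account rests on a few compounds, and the source may have more. Where it says the series, first, only, none or still open, it means among the compounds named here.

Compound 1 `COc1ccc(C(=O)CSc2nc3ccccc3[nH]2)cc1OC` gives 52.6% in a functional assay on HT-29 cells (Homo sapiens) for inhibition, read by flow cytometry, tested at 10 uM (a lower number here means less inhibition, a higher number more inhibition at the concentration tested (going by the name of the read-out)), the highest of the two numbers reported, although compound 3 `COc1ccc(C(=O)CSc2nc3ccccc3[nH]2)cc1O`, at 49.7%, sits within the scatter of it. Compound 2 `O=C(CSc1nc2ccccc2[nH]1)c1ccc(F)cc1` was reported as "not active" (no number reported) in this assay, with no number given. Within the data shown here, the single step with a number, a number 2.9 percentage points lower from compound 1 to compound 3 (within the scatter), puts hydrogen in place of methyl on an oxygen on an aromatic ring and barely moves the read-out. Compound 4 `COc1ccc(C(=O)CSc2nc3ccccc3[nH]2)c(OC)c1OC` differs from compound 1 by methoxy in place of hydrogen on an aromatic carbon. Among the measured compounds shown here, no measured step adds a methoxy group, so the one step at hand only suggests that small changes at the methoxy-bearing ring leave this assay roughly unchanged. A step of a number 2.6 percentage points lower from compound 1 to compound 4 (within the scatter) is therefore expected, and compound 4 is estimated at 50%, within 25% to 70%.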

Compound 4, a percentage reported as inhibition, at one concentration (the size of the read-out at that concentration, not a potency): 50.1%
The estimate for compound 4 lay 0.1 percentage points below the measured number; the measured number falls inside the stated range.
By their numbers in this assay, from the lowest: compounds 3, 4 and 1 (each within the scatter of the next).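

In this assay, a methoxy group can enter on this aromatic carbon, ortho to a large group and ortho to a methoxy group, with a number 2.5 percentage points lower from compound 1 to compound 4 (within the scatter) as the result. The earlier step only replaced the methyl of an existing methoxy group with hydrogen, whereas this one shows that the ring can gain a group at a new place without leaving the scatter. No measurement shown explains this result. As far as these compounds go, whether an amine, a carboxylic acid or a longer alkoxy chain on this same carbon would give a similar read-out remains open.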